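A dimethylamino swap in a series at its limit

The source may hold more compounds than are shown below. What is called first, only, known or untested is meant among the compounds shown, and "the series" means these compounds.

In a functional assay on SW-620 cells (Homo sapiens) for antiproliferative activity, read by MTT assay, with a stated time of 24 h (on this read-out higher numbers stand for weaker inhibition and lower numbers for stronger inhibition), the measured compounds stand as follows, each value a limit:
Compound 1 `COc1cccc(/C=C/C(=O)c2ccc(OC)c3c2OC(C)(C)C=C3)c1` – > 10000 nM
Compound 2 `COc1ccc(C(=O)/C=C/c2ccc(F)cc2)c2c1C=CC(C)(C)O2` – > 10000 nM
Compound 3 `COc1ccc(C(=O)/C=C/c2cccc(F)c2)c2c1C=CC(C)(C)O2` – > 10000 nM

In this assay compound 3 has only a limit of > 10000 nM and no number. Compound 4 `COc1ccc(C(=O)/C=C/c2ccc(N(C)C)cc2)c2c1C=CC(C)(C)O2` carries 4-(dimethylamino)phenyl in place of 3-fluorophenyl on a double-bonded chain carbon bound to a double-bonded chain carbon, as 4-(dimethylamino)phenyl in place of 3-fluorophenyl on a double-bonded chain carbon bound to a double-bonded chain carbon sets out in full. Among the compounds with values here, three measured steps bear on this change, and none has a readable size. They are a step that the two limits leave unreadable from compound 1 to compound 2 and a step that the two limits leave unreadable from compound 1 to compound 3 and also a step that the two limits leave unreadable from compound 2 to compound 3 as the closest case. The whole record is the limit of > 10000 nM in this assay, at which 3 of the 3 values shown sit, and it offers no direction for the new group. The series gives no sign of a large gain, so compound 4 is expected to stay near the limit. The expected change is a step that the limit leaves unreadable from compound 3 to compound 4 and it is not expected to be readable with confidence. For compound 4 the estimated value is 12000 nM with an expected range from 3000 nM to 40000 nM as the measurement is awaited.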

Compound 4, half-maximal inhibitory concentration: 570 nM
For compound 4 the middle estimate is 21-fold (1.32 log units) above the measured one; measured number below the stated range.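

In this assay, within the data shown here, 4-(dimethylamino)phenyl on a double-bonded chain carbon bound to a double-bonded chain carbon gives the first readable number at this place, with an at least 17-fold lower number from compound 3 to compound 4 (1.24 log units; beyond the scatter) and, for dimethylamino in place of fluoro on an aromatic carbon, an at least 17-fold lower number from compound 2 to compound 4 (1.24 log units; beyond the scatter). The change from 3-methoxyphenyl gives a step of the same printed size, an at least 17-fold lower number from compound 1 to compound 4 (1.24 log units; beyond the scatter), so this place can respond strongly even though neither fluorophenyl group nor 3-methoxyphenyl gave a number. The steps among compound 1, compound 2 and compound 3 still cannot be read, and the other values remain limits: the limit of > 10000 nM in this assay, at which 3 of the 4 values shown sit.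

The compounds shown leave open whether dimethylamino itself is needed or whether a primary amine or a morpholine on the same aromatic carbon would also give a readable number. They also leave open how a carboxylic acid there would compare.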